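The source may hold more compounds than are shown below. What is called first, only, known or untested is meant among the compounds shown, and "the series" means these compounds.

Measured so far:
compound 1 `O=C(COc1ccc2c(=O)ccoc2c1)Nc1cccc(NC(=O)c2ccc(OC(F)(F)F)cc2)c1` — in an assay on isolated protein for inhibition of Rho-associated protein kinase 2 (Homo sapiens), read by scintillation counting, radiometric assay and 33P incorporation, with a stated time of 40 min, in the presence of a further agent that is not named here (on this read-out lower numbers stand for stronger inhibition and higher numbers for weaker inhibition), compound 1 gives 77 nM
compound 2 `O=C(COc1ccc2c(=O)ccoc2c1)Nc1cccc(NC(=O)c2cccc([N+](=O)[O-])c2)c1` — in this assay compound 2 gives 41 nM

Going by the values given here, compound 2 has the lowest of the two numbers in this assay; its nearest neighbour is compound 1, and the only step recorded, a 1.9-fold lower number from compound 1 to compound 2 (0.27 log units; within the scatter), lies within the scatter, so the two compounds cannot be separated.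

Compound 3 `Cc1cc(C(=O)Nc2cccc(NC(=O)COc3ccc4c(=O)ccoc4c3)c2)no1` is not yet measured. It differs from compound 2 by 5-methyl-1,2-oxazol-3-yl in place of 3-nitrophenyl on a carbonyl carbon. Among the compounds with values here, none of the measured steps bears directly on this change: the only one available exchanges one substituent on the same carbonyl carbon for another and stays within the scatter, which gives no direction. Compound 3 is therefore expected to land near compound 2, with no step beyond the scatter, a 1.7-fold higher number from compound 2 to compound 3 (0.23 log units; within the scatter). The estimate for compound 3 in this assay is 70 nM, expected between 25 nM and 220 nM.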

Compound 3, half-maximal inhibitory concentration: 5 nM
Compound 3: the middle estimate sits 14-fold (1.15 log units) above what was measured, outside the stated range (below it).
By their numbers in this assay, from the lowest: compound 3; then compounds 2 and 1 (each within the scatter of the next).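

At the carbonyl carbon whose other neighbour is the amide-type nitrogen, the group now makes a clear difference in this assay: 5-methyl-1,2-oxazol-3-yl replacing 3-nitrophenyl gives a step beyond the scatter (an 8.2-fold lower number from compound 2 to compound 3 (0.91 log units; beyond the scatter)), and replacing 4-(trifluoromethoxy)phenyl gives a large one (a 15-fold lower number from compound 1 to compound 3 (1.19 log units; beyond the scatter)). Going by these compounds alone, the only earlier exchange, between the two substituted phenyl groups (a 1.9-fold lower number from compound 1 to compound 2 (0.27 log units; within the scatter)), had stayed within the scatter and gave no sign of this. No measurement available here accounts for the difference.

The compounds shown leave open whether the drop in the number comes from the 1,2-oxazole ring or from its methyl, which the unsubstituted 1,2-oxazol-3-yl or an ethyl in place of the methyl would address. They also leave open whether other five-membered aromatic rings, such as a thiazole or a pyrazole, behave the same way.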